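A Fluorine Added to a Cyclobutyl Amide

This account rests on a few compounds, and the source may have more. Where it says the series, first, only, none or still open, it means among the compounds named here.

Compound 1 `C(#Cc1nc2c(s1)CN(C1CCCCC1)CC2)c1ccccc1` in an assay on HEK293 cells for positive allosteric modulation of metabotropic glutamate receptor 5 (Homo sapiens), read by FLIPR, with a stated time of 1 h (on this read-out higher numbers stand for an effect only at larger amounts of compound and lower numbers for an effect already at smaller amounts), gives > 10000 nM, which is a limit of the assay rather than a number.
Compound 2 `O=C(C1CCC1)N1CCc2nc(C#Cc3ccccc3)sc2C1` in this assay gives > 10000 nM, likewise a limit of the assay and not a number.

For the measured compounds named here, compound 2 therefore stands at the edge of the measured range, and the one other value shown stands at the same edge. Going by the values given here, the only step between measured compounds, a step that the two limits leave unreadable from compound 1 to compound 2, cannot be read because both of its values sit at the limit of > 10000 nM in this assay, at which 2 of the 2 values shown sit. It tells nothing about the size or direction of any change.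

Compound 3 `O=C(C1CC(F)C1)N1CCc2nc(C#Cc3ccccc3)sc2C1` differs from compound 2 by fluoro in place of hydrogen on a saturated ring carbon. No measured step touches a change of this kind, and the single step that is shown is itself unreadable, so the expectation for compound 3 rests only on where compound 2 stands. Compound 3 is expected to stay at the limit, so that a step that the limit leaves unreadable from compound 2 to compound 3 is expected to be no step beyond the scatter. The estimate for compound 3 is 15000 nM, with a range from 5000 nM to 50000 nM, and a high chance that this assay again reports only a limit.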

Compound 3, half-maximal effective concentration: 85 nM
For compound 3 the middle estimate is 180-fold (2.25 log units) above the measured one; measured number outside the range, below it.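

Fluoro in place of hydrogen on a saturated ring carbon of the four-membered ring gives an at least 110-fold lower number from compound 2 to compound 3 (2.07 log units; beyond the scatter) in this assay and is the first step here that can be read, so this one place on the cyclobutyl amide can shift the read-out strongly. The earlier pair could show nothing of the kind, because neither of its compounds gave a number: the limit of > 10000 nM in this assay, at which 2 of the 3 values shown sit.
Measured against the cyclohexyl amine, (3-fluorocyclobutyl)carbonyl gives an at least 110-fold lower number from compound 1 to compound 3 (2.07 log units; beyond the scatter) in the same assay read-out, while cyclobutylcarbonyl without the fluoro stays at the limit, so among these compounds a number appears only with the fluoro present.

From the compounds shown here alone, compound 2 gives only a limit and no number, so the true size of the step to compound 3 stays open. Also open, going by these compounds, is whether the change belongs to fluoro in particular or would also come with another group at this place, such as a hydroxyl, a methyl or a second fluorine on the same ring carbon.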